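A few compounds are considered here, and "the series" means these few. Any claim that something is new, unique, unknown or untested is made for them only; others in the source may bear on it.

Compounds measured so far in a functional assay on HEK293 cells (Homo sapiens) for cytotoxicity; a higher number here means that more compound is tolerated, a lower number that less compound is tolerated:

Compound 1 `COc1ccc([C@H]2CC(=O)N(C(=O)c3ccccc3)C2)cc1OC1CCCC1`: > 10000 nM, a limit.
Compound 2 `COc1ccc([C@H]2CC(=O)N(c3ccccc3)C2)cc1OC1CCCC1`: > 10000 nM, a limit.
Compound 3 `COc1ccc([C@H]2CC(=O)N(c3ccccc3N)C2)cc1OC1CCCC1`: > 10000 nM, a limit.

Compound 3 has no number of its own, only a limit, and it shares that position with the other two compounds: the limit of > 10000 nM in this assay, at which 3 of the 3 values shown sit. Compound 4 `COc1ccc([C@H]2CC(=O)N(c3cccc(C#N)c3)C2)cc1OC1CCCC1`, still unmeasured, carries 3-cyanophenyl in place of 2-aminophenyl on an amide-type nitrogen in a ring. For the measured compounds named here, three measured steps bear on this change: a step that the two limits leave unreadable from compound 1 to compound 2, a step that the two limits leave unreadable from compound 1 to compound 3 and a step that the two limits leave unreadable from compound 2 to compound 3. Going by the values given here, the first two replace the group on that same nitrogen, and the third adds amino to the aromatic ring. None of them has a size that can be carried over, so no step beyond the scatter is expected in this assay. The expected step is a step that the limit leaves unreadable from compound 3 to compound 4. For compound 4 the estimated half-maximal cytotoxic concentration is 15000 nM, with an expected range from 8000 nM to 40000 nM.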

Compound 4, half-maximal cytotoxic concentration: > 10000 nM
Compound 4 gave a limit, no number; the forecaster's own chance of this, stated with the estimate: 90%; the middle value lies beyond the limit too.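

Compound 4, like compound 1, compound 2 and compound 3, gives only a limit in this assay, so no step among these compounds can be read: the limit of > 10000 nM in this assay, at which 4 of the 4 values shown sit.
The compounds shown leave open what half-maximal cytotoxic concentration any of them has, and whether the groups on that nitrogen differ at all.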